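An ethoxy group in place of fluoro on compound 1

The compounds below may be only part of what the source reports. "The series", "measured", "known", "first", "only" and "open" are said of these compounds alone.

Measured compounds in a functional assay on the whole organism (strain Sprague-Dawley) for inhibition, with Rattus norvegicus as the target; a lower number here means that less compound is needed, a higher number that more compound is needed for the effect:
compound 1 `O=C(O)c1cnc2c(F)cccc2c1` gives > 25 mg/kg, which is a limit of the assay.
compound 2 `O=C(O)c1cnc2c(F)cc(F)cc2c1` gives 25 mg/kg.
compound 3 `O=C(O)c1cnc2ccc(OC3CCCCC3)cc2c1` gives > 25 mg/kg, which is a limit of the assay.

Compound 1 stands at the limit of > 25 mg/kg in this assay, at which 2 of the 3 values shown sit, so for compound 1 only a limit and no number is known. For the measured compounds named here, the one measured step that touches compound 1, fluoro in place of hydrogen on an aromatic carbon, is a number no higher from compound 1 to compound 2 (the limit leaves the size open); its size cannot be read because compound 1 sits at the limit of > 25 mg/kg in this assay, at which 2 of the 3 values shown sit. Compound 3 likewise sits at the limit, so its value and that of compound 1 show only that both lie at the same limit.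

Compound 4 `CCOc1cccc2cc(C(=O)O)cnc12` differs from compound 1 by ethoxy in place of fluoro on an aromatic carbon. Going by the values given here, no measured step covers this change, and the only step from compound 1 is of open size. With nothing beyond the scatter to build on, compound 4 is estimated at 30 mg/kg, with a range from 8 mg/kg to 100 mg/kg. That estimate means an expected step that the limit leaves unreadable from compound 1 to compound 4, most likely ending again at a limit rather than a number.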

Compound 4, minimum effective dose: > 25 mg/kg
Compound 4 gave a limit, no number; the forecaster's own chance of this, stated with the estimate: 65%; the middle value lies beyond the limit too.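

In this assay compound 4 gives > 25 mg/kg, which is a limit and not a number. The step from compound 1 to compound 4 therefore cannot be read: the limit of > 25 mg/kg in this assay, at which 3 of the 4 values shown sit.

The compounds shown leave open what number compound 1 or compound 4 would give, and so whether ethoxy in place of fluoro changes the dose needed at all.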